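Dichlorophenyl for Methoxyphenyl in a Pair of Compounds with Low Numbers

The source may report more compounds than this note shows. Statements on the series, on what has been measured and on what is new or still open speak of the compounds shown alone.

Of the compounds shown here, two sharing one core have been tested in an assay on isolated protein for inhibition of serine protease 1 (Homo sapiens), tested at 100 uM; on this read-out higher numbers stand for more inhibition at the one concentration tested (going by the name of the read-out) and lower numbers for less inhibition. Compound 1 `CC1CCCC(C)N1CCCCCN1C(=O)C(c2ccccc2)Oc2ccccc21` gives 2.8% in this assay, and compound 2 `COc1ccc(C2Oc3ccccc3N(CCCCCN3C(C)CCCC3C)C2=O)cc1` gives 2.3%. Among the measured compounds shown here, compound 2 holds the lowest of the two numbers, but its only neighbour, compound 1, lies within the scatter, the single measured step being a number 0.5 percentage points lower from compound 1 to compound 2 (within the scatter) for a methoxy in place of hydrogen on an aromatic carbon. Compound 3 `CC1CCCC(C)N1CCCCCN1C(=O)C(c2ccc(Cl)c(Cl)c2)Oc2ccccc21` has not yet been measured. It differs from compound 2 in one place: 3,4-dichlorophenyl in place of 4-methoxyphenyl on a saturated ring carbon. For the measured compounds named here, the one measured step bears on it only loosely, since it also alters the aromatic ring on that saturated ring carbon, and it stayed within the scatter. Going by the values given here, no measured pair shows a chlorine entering or a methoxy leaving. Both measured numbers sit low in this assay, so compound 3 is expected to remain in the same region, with a step of a number 1.7 percentage points higher from compound 2 to compound 3 (within the scatter) estimated as no change beyond the scatter. Compound 3 is therefore estimated to give 4%, with a range from 0% to 15%.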

Compound 3, a percentage reported as inhibition, at one concentration (the size of the read-out at that concentration, not a potency): 14%
Beside the measured number, compound 3's estimate is 10 percentage points below it; the measured number falls inside the stated range.
By their numbers in this assay, from the lowest: compounds 2 and 1 (each within the scatter of the next); then compound 3.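

In this assay, the aromatic group on this saturated ring carbon, next to the ring oxygen, proves able to move the read-out: 3,4-dichlorophenyl in place of 4-methoxyphenyl gives a number 11.7 percentage points higher from compound 2 to compound 3 (beyond the scatter), and 3,4-dichlorophenyl in place of phenyl gives a number 11.2 percentage points higher from compound 1 to compound 3 (beyond the scatter). Among the compounds shown here, the earlier change, methoxy in place of hydrogen on the same aromatic ring, had stayed within the scatter, so these are the first steps in the set to go beyond it, and the rise appears from both of the compounds that lack chlorine. Nothing available here accounts for this rise, which remains a modest change in inhibition at a single concentration rather than a measure of potency.

As far as these compounds go, these compounds do not separate the contribution of the two chlorines, so it remains open whether a single chlorine on the ring would give a similar number. From the compounds shown here alone, it also remains open how this position would respond to a trifluoromethyl group, a nitrile or an amine on the aromatic ring, or to a different aromatic ring altogether.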